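A few compounds are considered here, and "the series" means these few. Any claim that something is new, unique, unknown or untested is made for them only; others in the source may bear on it.

Measured compounds: compound 1 `CCN(CC)S(=O)(=O)c1ccc(S(=O)(=O)N2CCC[C@@H](C(=O)N3CC[C@@H](OC)C3)C2)cc1` gives 11500 nM; compound 2 `CCN(CC)S(=O)(=O)c1ccc(S(=O)(=O)N2CCC[C@@H](C(=O)N[C@H]3CC[C@@H](OC)CC3)C2)cc1` gives 2150 nM; compound 3 `CCN(CC)S(=O)(=O)c1ccc(S(=O)(=O)N2CCC[C@@H](C(=O)N3CC[C@H](OC)C3)C2)cc1` gives 6750 nM, all in a functional assay on BXPC-3 cells (Homo sapiens) for inhibition, read by MTT assay, with a stated time of 7 days; on this read-out lower numbers stand for stronger inhibition and higher numbers for weaker inhibition.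

Compound 3 stands second highest of the three numbers; its gap to compound 1, a 1.7-fold lower number from compound 1 to compound 3 (0.23 log units; within the scatter), is within the scatter, while compound 2 sits clearly lower, as a 3.1-fold higher number from compound 2 to compound 3 (0.50 log units; beyond the scatter) shows. Compound 4 `CCN(CC)S(=O)(=O)c1ccc(S(=O)(=O)N2CCC[C@@H](C(=O)NC3CCOCC3)C2)cc1` is not yet measured. It differs from compound 3 in one place: (oxan-4-yl)amino in place of 3-methoxypyrrolidin-1-yl on a carbonyl carbon. Among the compounds with values here, two measured steps bear on this change, a 5.3-fold lower number from compound 1 to compound 2 (0.73 log units; beyond the scatter) and a 3.1-fold higher number from compound 2 to compound 3 (0.50 log units; beyond the scatter), both favouring the secondary amide with a six-membered ring over 3-methoxypyrrolidin-1-yl. Compound 4 is therefore expected to give a modestly lower number, a 2.3-fold lower number from compound 3 to compound 4 (0.35 log units; beyond the scatter), with an estimate of 3000 nM and a range from 1200 nM to 7500 nM.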

Compound 4, half-maximal inhibitory concentration: 8570 nM
Beside the measured number, compound 4's estimate is 2.9-fold (0.46 log units) below it, outside the stated range (above it).
By their numbers in this assay, from the lowest: compound 2; then compounds 3, 4 and 1 (each within the scatter of the next).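

In this assay, the secondary amide alone does not set the number: a 1.3-fold higher number from compound 3 to compound 4 (0.10 log units; within the scatter) and a 1.3-fold lower number from compound 1 to compound 4 (0.13 log units; within the scatter) both stay within the scatter, so (oxan-4-yl)amino in place of 3-methoxypyrrolidin-1-yl on a carbonyl carbon changes little. The change that counts is oxan-4-yl in place of 4-methoxycyclohexyl on an amide-type nitrogen, with a 4.0-fold higher number from compound 2 to compound 4 (0.60 log units; beyond the scatter). Both pyrrolidine comparisons read alike, and they concern a single pair of isomers: the fact that compounds 1 and 3 differ only in the configuration as drawn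

Going by these compounds, whether the lower number of compound 2 goes with its methoxy group or with its cyclohexyl ring stays open. A plain cyclohexyl group on the amide-type nitrogen would tell these apart.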